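A few compounds are considered here, and "the series" means these few. Any claim that something is new, unique, unknown or untested is made for them only; others in the source may bear on it.

In a functional assay on DU-145 cells (Homo sapiens) for cytotoxicity, read by MTT assay (on this read-out higher numbers stand for weaker inhibition and lower numbers for stronger inhibition), three compounds sharing one core have been measured. Compound 1 `CC(C)=CC[C@@H](OC(=O)CCO)C1=CC(=O)c2c(O)ccc(O)c2C1=O` gives 55300 nM. Compound 3 `CC[C@](C)(O)CC(=O)O[C@H](CC=C(C)C)C1=CC(=O)c2c(O)ccc(O)c2C1=O` gives 20500 nM, the lower of the two actual numbers in the set. For compound 2 `CC(C)=CC[C@@H](OC(=O)c1ccco1)C1=CC(=O)c2c(O)ccc(O)c2C1=O`, the read-out is a limit, > 100000 nM, and not a number.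

Compound 4 `CCCCCCC(C)(O)CC(=O)O[C@H](CC=C(C)C)C1=CC(=O)c2c(O)ccc(O)c2C1=O` has not yet been measured. It departs from compound 3 at a single place, on a saturated chain carbon bound to a carbonyl carbon: 1-hydroxy-1-methylheptyl in place of 1-hydroxy-1-methylpropyl on a saturated chain carbon bound to a carbonyl carbon. In words, 1-hydroxy-1-methylheptyl stands in place of 1-hydroxy-1-methylpropyl.

Within the data shown here, no measured step makes this exact change. The closest is a 2.7-fold lower number from compound 1 to compound 3 (0.43 log units; beyond the scatter), where 1-hydroxy-1-methylpropyl replaces hydroxymethyl at the same place. The other two steps bear on it less, since both involve furan-2-yl and rest on a limit: an at least 1.8-fold higher number from compound 1 to compound 2 (0.25 log units; that floor lies within the scatter) and an at least 4.8-fold lower number from compound 2 to compound 3 (0.68 log units; beyond the scatter).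

With that single modest step as the guide, a further move towards a lower number is expected in this assay, of about the same size or smaller. The expected change is a 2.1-fold lower number from compound 3 to compound 4 (0.31 log units; beyond the scatter). The value for compound 4 is estimated at 10000 nM, with an expected range from 3000 nM to 30000 nM.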

Compound 4, half-maximal inhibitory concentration: > 100000 nM
Compound 4: a limit, no number; the forecaster's own chance of this, stated with the estimate: 5%; middle value at least 10-fold (1.00 log units) away from the limit.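

In this assay, the two changes at this place, on a saturated chain carbon bound to a carbonyl carbon, do not run in one direction: a 2.7-fold lower number from compound 1 to compound 3 (0.43 log units; beyond the scatter) is followed by an at least 4.8-fold higher number from compound 3 to compound 4 (0.68 log units; beyond the scatter), so the gain seen with 1-hydroxy-1-methylpropyl does not carry over to 1-hydroxy-1-methylheptyl. Set against the hydroxymethyl of compound 1, the longer chain gives an at least 1.8-fold higher number from compound 1 to compound 4 (0.25 log units; that floor lies within the scatter), so compound 4 shows no gain over that small group, although this floor does not clear the scatter. The value of compound 4 is a limit and not a number, so these sizes are floors, and the step linking compound 2 and compound 4 cannot be read: the limit of > 100000 nM in this assay, at which 2 of the 4 values shown sit.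

How the number changes with chain length at this place remains open, since only the 1-hydroxy-1-methylpropyl and 1-hydroxy-1-methylheptyl groups are shown, and a 1-hydroxy-1-methylbutyl or 1-hydroxy-1-methylpentyl group would test whether the rise is gradual or abrupt. From the compounds shown here alone, it is also open whether an amine in place of the hydroxy group on these chains would change the read-out.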